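The compounds below may be only part of what the source reports. "The series", "measured", "known", "first", "only" and "open" are said of these compounds alone.

The study follows four nucleoside analogues in a functional assay on L1210 cells (Mus musculus), read by MTT assay; a higher number here means a weaker inhibitor, a lower number a stronger inhibitor. Compound 2 `CC#C[C@@]1(O)[C@@H](CO)O[C@@H](n2ccc(N)nc2=O)[C@@H]1O` gives 24500 nM, the lowest of the two numbers obtained. Compound 3 `CC#C[C@@]1(O)[C@@H](CO)O[C@@H](n2ccc(=O)[nH]c2=O)[C@@H]1O` gives 354000 nM in this assay, a figure that stands beyond the scatter above that of compound 2; how the core of compound 2 differs from the core of compound 3 is not broken down here. Compound 1 `O=c1ccn([C@@H]2O[C@H](CO)[C@](O)(C3CC3)[C@H]2O)c(=O)[nH]1` gives > 350000 nM in this assay, and that value is a limit of the assay, not a number. The change from compound 3 to compound 1 is cyclopropyl in place of prop-1-yn-1-yl on a saturated ring carbon; it makes the step that the limit leaves unreadable from compound 3 to compound 1, whose size stays hidden because of the limit of > 350000 nM in this assay, at which 1 of the 3 values shown sits.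

Compound 4 `Nc1ccn([C@@H]2O[C@H](CO)[C@](O)(C3CC3)[C@H]2O)c(=O)n1` has yet to be measured. Among the compounds with values here, it differs from compound 2 by cyclopropyl in place of prop-1-yn-1-yl on a saturated ring carbon, the same change as the one from compound 3 to compound 1, and at a place described in the same words. Since the measured instance of this change cannot be read, the expectation for compound 4 leans on the direction hinted at by compound 1 reaching > 350000 nM in this assay. The author therefore expects the step from compound 2 to compound 4 to be a loss of roughly a 6.1-fold higher number from compound 2 to compound 4 (0.79 log units; beyond the scatter), set beside the unreadable earlier one. Compound 4 is estimated at 150000 nM, most likely between 40000 nM and 400000 nM.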

Compound 4, half-maximal inhibitory concentration: > 350000 nM
Compound 4: no number, only a limit (the forecaster's own chance of this, stated with the estimate: 35%); middle value at least 2.3-fold (0.36 log units) away from the limit.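

Compound 4 gives > 350000 nM in this assay, and that value is a limit of the assay, not a number. On the core of compound 2, cyclopropyl in place of prop-1-yn-1-yl on a saturated ring carbon gives an at least 14-fold higher number from compound 2 to compound 4 (1.15 log units; beyond the scatter), so in this pair the change costs far more than the usual scatter, and the measurable value of compound 2 is lost. What this does not show is whether the change carries over from one core to the other with the same size, since the step from compound 3 to compound 1 cannot be read and the two steps cannot be set against each other: the limit of > 350000 nM in this assay, at which 2 of the 4 values shown sit.

The compounds shown leave open how an amine, a fluorine atom or a longer alkyne chain would read in place of prop-1-yn-1-yl on this saturated ring carbon, on either core. They also leave open whether any group in that place on the core of compound 2 would give a lower number than compound 2, which gives 24500 nM in this assay.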